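Trisulfated glycoside amides: replacing a benzyl group on nitrogen

This account rests on a few compounds, and the source may have more. Where it says the series, first, only, none or still open, it means among the compounds named here.

Measured compounds:
Compound 1, `CO[C@H]1O[C@H](CNC(=O)CN(Cc2ccccc2)C(C)=O)[C@@H](OS(=O)(=O)O)[C@H](OS(=O)(=O)O)[C@@H]1OS(=O)(=O)O`: 192000 nM
Compound 2, `CO[C@H]1O[C@H](CNC(=O)CN(C(C)=O)C2CCCCCC2)[C@@H](OS(=O)(=O)O)[C@H](OS(=O)(=O)O)[C@@H]1OS(=O)(=O)O`: 410000 nM
Compound 3, `CO[C@H]1O[C@H](CNC(=O)CN(C(C)=O)C2CCCCC2)[C@@H](OS(=O)(=O)O)[C@H](OS(=O)(=O)O)[C@@H]1OS(=O)(=O)O`: 413000 nM

All three were tested in an assay on isolated protein for binding affinity to fibroblast growth factor 2 (Homo sapiens), read by surface plasmon resonance; on this read-out higher numbers stand for weaker binding and lower numbers for tighter binding. Compound 1 gives the lowest number of the three, with compound 2 nearest and compound 3 furthest, both beyond the scatter. The two measured steps, a 2.1-fold higher number from compound 1 to compound 2 (0.33 log units; beyond the scatter) and a 2.2-fold higher number from compound 1 to compound 3 (0.33 log units; beyond the scatter), each show a modest rise when the benzyl group on the amide-type nitrogen is exchanged for a saturated ring, while the pair of compounds 2 and 3 shows a 1.0-fold higher number from compound 2 to compound 3 (0.00 log units; within the scatter).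

Compound 4, `CCN(CC(=O)NC[C@H]1O[C@H](OC)[C@@H](OS(=O)(=O)O)[C@@H](OS(=O)(=O)O)[C@@H]1OS(=O)(=O)O)C(=O)CCCCC(=O)O`, is not yet measured. It differs from compound 1 by ((4-carboxybutyl)carbonyl)(ethyl)amino in place of acetyl(benzyl)amino on a saturated chain carbon bound to a carbonyl carbon. The measured steps bear on it only in part: they show that removing the benzyl group in favour of a group without an aromatic ring costs a modest amount, but none of them touches the acetyl group or introduces a carboxylic acid, so the remaining part of the change is unsupported by data. On that basis the step from compound 1 to compound 4 is expected to be a modest weakening, a 1.8-fold higher number from compound 1 to compound 4 (0.26 log units; within the scatter), with wide uncertainty. Compound 4 is therefore estimated at 350000 nM, ranging from 140000 nM to 900000 nM.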

Compound 4, dissociation constant: 480000 nM
The estimate for compound 4 lay 1.4-fold (0.14 log units) below the measured number; the range from low to high includes it.
By their numbers in this assay, from the lowest: compound 1; then compounds 2, 3 and 4 (each within the scatter of the next).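

In this assay, the ringless ((4-carboxybutyl)carbonyl)(ethyl)amino group gives a 2.5-fold higher number from compound 1 to compound 4 (0.40 log units; beyond the scatter), so compound 1 stays apart from all three other compounds. Against the saturated rings, the same group gives a 1.2-fold higher number from compound 3 to compound 4 (0.07 log units; within the scatter) and a 1.2-fold higher number from compound 2 to compound 4 (0.07 log units; within the scatter), so at this place an open chain carrying a carboxylic acid cannot be told from the acetyl-bearing cyclohexyl and cycloheptyl groups. No measurement at hand accounts for this result.

Compound 4 alters both groups on the nitrogen at once, so the share of ethyl in place of the ring and the share of the longer acyl chain in place of acetyl cannot be separated. Also open, as far as these compounds go, is whether benzyl paired with the (4-carboxybutyl)carbonyl group, or an amine in place of the carboxylic acid, would read differently.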